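The source may report more compounds than this note shows. Statements on the series, on what has been measured and on what is new or still open speak of the compounds shown alone.

Compound 1 `COc1cc(/C=C/C(=O)c2ccc(OC)c([N+](=O)[O-])c2)cc(OC)c1` and compound 2 `COc1cc(/C=C/C(=O)c2ccc(OC)c(N)c2)cc(OC)c1` share one core. In a functional assay on B16 cells (Mus musculus) for cytotoxicity, read by MTT assay, with a stated time of 3 days (on this read-out lower numbers stand for stronger inhibition and higher numbers for weaker inhibition), compound 1 gives 5600 nM, and compound 2 gives 8800 nM. The step of a 1.6-fold higher number from compound 1 to compound 2 (0.20 log units; within the scatter) follows from the change (amino in place of nitro on an aromatic carbon). Compound 3 `COc1ccc(/C=C/C(=O)c2cc(OC)c(OC)c(OC)c2)cc1[N+](=O)[O-]` is built on a different core, and how its core differs from that of compound 1 is not broken down here. For compound 3 the assay returns only a limit, > 100000 nM, which is the limit of > 100000 nM in this assay, at which 1 of the 3 values shown sits. Compound 4 `COc1ccc(/C=C/C(=O)c2cc(OC)c(OC)c(OC)c2)cc1N` has not yet been measured and differs from compound 3 by amino in place of nitro on an aromatic carbon, the same change that leads from compound 1 to compound 2. Because the step of a 1.6-fold higher number from compound 1 to compound 2 (0.20 log units; within the scatter) stayed within the scatter, the step that the limit leaves unreadable from compound 3 to compound 4 is expected to be small as well. Compound 4 is therefore estimated at 150000 nM, with a range from 60000 nM to 400000 nM, and will most likely again be reported only as a limit.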

Compound 4, half-maximal inhibitory concentration: 240 nM
Estimate against measurement, compound 4: 630-fold (2.80 log units) above; measured number outside the range, below it.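

In this assay amino in place of nitro gives an at least 410-fold lower number from compound 3 to compound 4 (2.61 log units; beyond the scatter) and so differs sharply from what the same change does on the core of compound 1. The change therefore does not carry over from one core to the other with the same size in this series: the same change on two cores in this assay, a 1.6-fold higher number (0.20 log units; within the scatter) from compound 1 to compound 2 and an at least 410-fold lower number (2.61 log units; beyond the scatter) from compound 3 to compound 4, at least 650-fold (2.81 log units) apart, beyond the scatter of two such steps. Going by these compounds, compound 3 gives only a limit, > 100000 nM, so the full size of its step stays unknown, and nothing here shows which difference between the two cores is responsible.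

The compounds shown leave open whether a hydroxyl or an acetamide in the same place would behave like the amino on either core. They also leave open how the change behaves on any third core.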